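Methoxy for chloro on a core held at the limit

The compounds below may be only part of what the source reports. "The series", "measured", "known", "first", "only" and "open" are said of these compounds alone.

Compound 1, `CN1CCN(CCNC(=O)n2c(=O)n(Cc3ccccc3)c3ccccc32)CC1`, in an assay on isolated protein for displacement of a labelled ligand from 5-hydroxytryptamine receptor 4 (Cavia porcellus) (a higher number here means a weaker inhibitor, a lower number a stronger inhibitor), gives > 1000 nM, a limit of the assay.
Compound 2, `C=CCn1c(=O)n(C(=O)NCCN2CCN(C)CC2)c2ccccc21`, in this assay gives > 1000 nM, again a limit.
Compound 3, `CC(C)n1c(=O)n(C(=O)NCCN2CCN(C)CC2)c2cc(Cl)ccc21`, in this assay gives > 1000 nM, also a limit.

Compound 3 therefore stands where every measured value in this set stands: at the limit of > 1000 nM in this assay, at which 3 of the 3 values shown sit. For the measured compounds named here, the only single-site step among the measured compounds, a step that the two limits leave unreadable from compound 1 to compound 2, runs between two limits and cannot be read in size or direction.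

Compound 4, `COc1ccc2c(c1)n(C(=O)NCCN1CCN(C)CC1)c(=O)n2C(C)C`, differs from compound 3 in one place: methoxy in place of chloro on an aromatic carbon. Going by the values given here, no measured step touches this position or this exchange, so nothing in the data sets a direction. The three limits together make it likely that compound 4 will also be reported only as a limit in this assay, with a weak result the most probable outcome. Compound 4 is expected to give 3000 nM, in a range from 800 nM to 20000 nM. The expected step is a step that the limit leaves unreadable from compound 3 to compound 4, not readable beyond the scatter.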

Compound 4, half-maximal inhibitory concentration: > 1000 nM
Compound 4: only a limit was reported; the forecaster's own chance of this, stated with the estimate: 80%; the middle value is on the limit's open side.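

The results for compound 3 and compound 4 are both limits, so the step between them cannot be read in size or direction: the limit of > 1000 nM in this assay, at which 4 of the 4 values shown sit.

The compounds shown leave open what actual value any of them has in this assay, and whether exchanging chloro for methoxy changes it.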